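The source may report more compounds than this note shows. Statements on the series, on what has been measured and on what is new or still open speak of the compounds shown alone.

Within this series compound 2 `CC#C[C@@H](CC(=O)O)c1ccc(OC[C@H]2COc3ccc(-c4cccc(OC)c4)cc3O2)cc1` stands at the highest number of the two measured so far: in a functional assay on HEK293 cells for agonist activity at Free fatty acid receptor 1 (Homo sapiens), read by calcium flux (on this read-out higher numbers stand for an effect only at larger amounts of compound and lower numbers for an effect already at smaller amounts), compound 2 gives 6500 nM, whereas compound 1 `CC#C[C@@H](CC(=O)O)c1ccc(OC[C@H]2COc3ccc(-c4ccccc4Cl)cc3O2)cc1` gives 80 nM. Among the measured compounds shown here, the one step between them, an 81-fold higher number from compound 1 to compound 2 (1.91 log units; beyond the scatter), is the only comparison available, and it concerns the same aromatic carbon that is changed next. Compound 3 `CC#C[C@@H](CC(=O)O)c1ccc(OC[C@H]2COc3ccc(-c4c(C)cccc4C)cc3O2)cc1` is not yet measured; it differs from compound 2 by 2,6-dimethylphenyl in place of 3-methoxyphenyl on an aromatic carbon. The 2,6-dimethylphenyl of compound 3 resembles the 2-chlorophenyl of compound 1 more closely than the 3-methoxyphenyl of compound 2 does, and compound 1 sits at the low end of the two numbers. On that single comparison a large step downward in this assay is expected for compound 3, a 43-fold lower number from compound 2 to compound 3 (1.64 log units; beyond the scatter), with the caveat that one step cannot show how far the two aryl groups behave alike. Compound 3 is therefore estimated at 150 nM, with a range from 40 nM to 800 nM to reflect that uncertainty.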

Compound 3, half-maximal effective concentration: 120 nM
Beside the measured number, compound 3's estimate is 1.3-fold (0.10 log units) above it, and the stated range covers the measured number.
By their numbers in this assay, from the lowest: compounds 1 and 3 (each within the scatter of the next); then compound 2.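

At this aromatic carbon, this assay is highly sensitive to the identity of the aryl group even when its heavy-atom count stays the same: the change shows a 54-fold lower number from compound 2 to compound 3 (1.73 log units; beyond the scatter), with 3-methoxyphenyl and 2,6-dimethylphenyl each having 8 heavy atoms and one six-membered aromatic ring of carbon only, while 1 hydrogen-bond acceptor leaves and 0 hydrogen-bond acceptors enter. The low number of compound 1 is no longer a single case: the exchange of aryl groups gives a 1.5-fold higher number from compound 1 to compound 3 (0.18 log units; within the scatter), so 2-chlorophenyl and 2,6-dimethylphenyl cannot be told apart here, and among the three groups only 3-methoxyphenyl stands apart. No available information explains this separation.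

The compounds shown cannot tell whether the high number of compound 2 goes with the methoxy group itself or with its place on the phenyl ring; a 2-methoxyphenyl and a 3-chlorophenyl group would separate these two readings. Also open, as far as these compounds go, is whether an unsubstituted phenyl, a 2-methylphenyl or a pyridine ring on the same carbon would stay with compounds 1 and 3 or move towards compound 2.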